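The compounds below may be only part of what the source reports. "The series", "measured", "known", "first", "only" and "open" are said of these compounds alone.

Of the compounds shown here, three sharing one core have been tested in a functional assay on K562 cells (Homo sapiens) for cytotoxicity, read by MTT assay, with a stated time of 24 h; on this read-out lower numbers stand for stronger inhibition and higher numbers for weaker inhibition. Compound 1 `COc1cc(/C=C2\CN(C)C/C(=C\c3ccccc3F)C2=O)cc(OC)c1` gives 6320 nM. Compound 2 `COc1cc(/C=C2\CN(C)C/C(=C\c3ccccc3F)C2=O)cc(OC)c1OC` gives 4340 nM. Compound 3 `COc1cc(/C=C2\CN(C)C/C(=C\c3ccc(Cl)cc3)C2=O)cc(OC)c1` gives 13300 nM, the highest of the three numbers and clearly apart from the other two. Compound 4 `COc1cc(/C=C2\CN(C)C/C(=C\c3ccc(Cl)cc3Cl)C2=O)cc(OC)c1` differs from compound 3 in one place: chloro in place of hydrogen on an aromatic carbon. This is chloro in place of hydrogen on an aromatic carbon, turning 4-chlorophenyl into 2,4-dichlorophenyl. Going by the values given here, no measured step makes exactly this change, but two bear on it. Methoxy in place of hydrogen on an aromatic carbon gave a 1.5-fold lower number from compound 1 to compound 2 (0.16 log units; within the scatter), so adding one group there changed little. Replacing 2-fluorophenyl with 4-chlorophenyl gave a 2.1-fold higher number from compound 1 to compound 3 (0.32 log units; beyond the scatter). Like compound 1 at 6320 nM, compound 4 would carry a halogen ortho to a large group, so a small move toward a lower number seems likely. The expected change is a 1.7-fold lower number from compound 3 to compound 4 (0.22 log units; within the scatter). Compound 4 is estimated at 8000 nM, with an expected range of 3500 nM to 18000 nM.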

Compound 4, half-maximal inhibitory concentration: 11900 nM
Beside the measured number, compound 4's estimate is 1.5-fold (0.17 log units) below it, and the stated range covers the measured number.
By their numbers in this assay, from the lowest: compounds 2, 1, 4 and 3 (each within the scatter of the next, the first and the last beyond it).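

In this assay, placing a second chloro group ortho to a large group, and meta to the existing chloro group, gives a 1.1-fold lower number from compound 3 to compound 4 (0.05 log units; within the scatter) and so produces no readable change. This position therefore accepts one added chlorine without any shift beyond the usual scatter, at least on this 4-chlorophenyl ring. The wider replacement of 2-fluorophenyl by 2,4-dichlorophenyl gives a 1.9-fold higher number from compound 1 to compound 4 (0.27 log units; within the scatter) and also stays within the scatter, whereas the replacement by 4-chlorophenyl alone went just beyond it, a narrow difference that should not be overread.

These compounds leave open whether a hydroxyl group, an amine or a carboxylic acid on this same ring carbon would be accepted as readily as chloro. No measurement shown here explains why this added chlorine leaves the number within the scatter.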